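Removing the bromo group from an aryl urea: an expected dose

The source may report more compounds than this note shows. Statements on the series, on what has been measured and on what is new or still open speak of the compounds shown alone.

Compounds measured so far:
compound 1, `CC(C)c1cccc(C(C)C)c1NC(=O)/N=C1\CCCN1C`, "not determined" (no result reported)
compound 2, `CN1CCC/C1=N\C(=O)Nc1cccc(Br)c1`, 25 mg/kg
compound 3, `CN1CCC/C1=N\C(=O)Nc1c(Br)cccc1Br`, > 25 mg/kg

The compounds were examined in a functional assay on the whole organism with Rattus norvegicus as the target, with a stated time of 5 days; on this read-out higher numbers stand for an effect only at larger amounts of compound and lower numbers for an effect already at smaller amounts. For compound 1 the outcome is "not determined" (no result reported). Going by the values given here, compound 2 gives 25 mg/kg, the only plain number in the set. For compound 3 only a limit is reported, > 25 mg/kg; this value marks the edge of what the assay resolves, as the limit of > 25 mg/kg in this assay, at which 1 of the 3 values shown sits, states. Compound 2 therefore stands alone as the single measured reference, with one limit and one missing entry beside it.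

The step to be followed is from compound 2 to compound 4, `CN1CCC/C1=N\C(=O)Nc1ccccc1`. The change is hydrogen in place of bromo on an aromatic carbon. Among the compounds with values here, no measured pair with the same change is available, so the size of the step cannot be read from the data. The step from compound 2 to compound 4 is expected to stay near the scatter, no change at the digits printed from compound 2 to compound 4 (within the scatter), with the dose possibly drifting upward. Compound 4 is estimated at 25 mg/kg, with a likely range from 12 mg/kg to 60 mg/kg.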

Compound 4, minimum effective dose: 15 mg/kg
Estimate against measurement, compound 4: 1.7-fold (0.22 log units) above, and the stated range covers the measured number.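

In this assay, going by these compounds alone, the change from bromo to hydrogen gives the first readable step of this set, a 1.7-fold lower number from compound 2 to compound 4 (0.22 log units; within the scatter). At this place, meta to a large group, the bromo group is therefore not required for an effect in the whole animal, and compound 4 adds a second plain number to the single one available before. The step sets no order between the two compounds, so this change shows only that the dose holds within the usual scatter when the bromo group leaves.

Compound 3 is reported only as a limit, and that edge of the assay still stands: the limit of > 25 mg/kg in this assay, at which 1 of the 4 values shown sits.
From the compounds shown here alone, whether another group at this place, such as a methoxy group, an amine or a carboxylic acid, would move the dose beyond the scatter remains open.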